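The source may report more compounds than this note shows. Statements on the series, on what has been measured and on what is new or still open speak of the compounds shown alone.

Measured compounds in a functional assay on A549 cells (Homo sapiens) for inhibition, read by MTT assay, with a stated time of 48 h, tested at 10 uM; on this read-out lower numbers stand for less inhibition of growth and higher numbers for more inhibition of growth at the one concentration tested:
compound 1, `COc1ccc(C(=O)/C=C/c2ccc(OCc3cn(Cc4cccc(Br)c4)nn3)cc2)cc1`, gives 47%
compound 2, `COc1ccc(C(=O)/C=C/c2ccc(OCc3cn(Cc4ccc(F)cc4)nn3)cc2)cc1`, gives 33%

Compound 1 holds the highest of the two numbers in this assay; its nearest neighbour is compound 2, and the step of a number 14 percentage points lower from compound 1 to compound 2 (beyond the scatter), a 4-fluorophenyl in place of 3-bromophenyl on a saturated chain carbon bound to an aromatic nitrogen, lies beyond the scatter. Compound 3, `O=C(/C=C/c1ccc(OCc2cn(Cc3cccc(Br)c3)nn2)cc1)c1ccc([N+](=O)[O-])cc1`, has not been measured. It differs from compound 1 by nitro in place of methoxy on an aromatic carbon of a six-membered aromatic ring of carbon only, para to a large group; read one bond further out, a 4-methoxyphenyl becomes a 4-nitrophenyl. Among the measured compounds shown here, the only measured step concerns the other end of the shared core and leaves this position untouched, so no measured step bears directly on the change. Without such a step, the estimated step is no change at the digits printed from compound 1 to compound 3 (within the scatter), none beyond the scatter, with a wide range around it. Compound 3 is therefore expected to give about 47% in this assay, within a range from 25% to 68%.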

Compound 3, percent growth inhibition at one concentration: 28%
The estimate for compound 3 lay 19 percentage points above the measured number, and the stated range covers the measured number.
By their numbers in this assay, from the lowest: compounds 3 and 2 (each within the scatter of the next); then compound 1.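

In this assay, the change from a 4-methoxyphenyl to a 4-nitrophenyl gives a number 19 percentage points lower from compound 1 to compound 3 (beyond the scatter), so this end of the molecule does bear on the read-out, which the earlier step at the other end of the shared core could not show. With the 3-bromophenyl held constant, methoxy on this aromatic carbon goes with more inhibition of growth at the one concentration tested than nitro does, and the replacement alone is enough to carry the number beyond the usual scatter. Nothing available explains why the number moves in this direction at this position.

The compounds shown leave open how an amine, a hydroxy group or a longer ether chain such as ethoxy would read on this same aromatic carbon, as two groups at one position do not establish a trend. From the compounds shown here alone, it also remains open whether the step from methoxy to nitro would be of similar size with a 4-fluorophenyl at the other end of the core.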